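Ester chain length on a fused bicyclic enone and cytotoxicity

The compounds below may be only part of what the source reports. "The series", "measured", "known", "first", "only" and "open" are said of these compounds alone.

Measured compounds:
compound 1 `CC(=O)O[C@]12C=CC(=O)C[C@H]1OCC2`, 0.5 ug/mL
compound 2 `CCCC(=O)O[C@]12C=CC(=O)C[C@H]1OCC2`, 0.6 ug/mL
compound 3 `CCCCCC(=O)O[C@]12C=CC(O)C[C@H]1OCC2`, 38.5 ug/mL

In a functional assay on P388 cells (Mus musculus) for cytotoxicity (a lower number here means a stronger inhibitor, a higher number a weaker inhibitor), compound 1 gives 0.5 ug/mL and compound 2 gives 0.6 ug/mL. Compound 2 carries ethyl in place of hydrogen on a saturated chain carbon bound to a carbonyl carbon, and the step of a 1.2-fold higher number from compound 1 to compound 2 (0.08 log units; within the scatter) shows this change to leave the read-out essentially where it was. Compound 3, in this assay, gives 38.5 ug/mL; the difference between its core and that of compound 1 is not broken down here. Compound 4 `CCCCCCCC(=O)O[C@]12C=CC(O)C[C@H]1OCC2` bears ethyl in place of hydrogen on a saturated chain carbon, five bonds along the chain from a carbonyl carbon. This is the same kind of change as from compound 1 to compound 2, but its place differs: on a saturated chain carbon bound to a carbonyl carbon there, five bonds along the chain from a carbonyl carbon here. Resting on the small step of a 1.2-fold higher number from compound 1 to compound 2 (0.08 log units; within the scatter), the step of a 1.3-fold lower number from compound 3 to compound 4 (0.11 log units; within the scatter) is expected to be modest as well. Compound 4 is thus estimated at 30 ug/mL, between 10 ug/mL and 80 ug/mL.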

Compound 4, half-maximal inhibitory concentration: 8.4 ug/mL
The estimate for compound 4 lay 3.6-fold (0.55 log units) above the measured number; the whole stated range lies above it.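

In this assay, within the data shown here, ethyl in place of hydrogen on the ester chain gives a 4.6-fold lower number from compound 3 to compound 4 (0.66 log units; beyond the scatter), and this step does not match the one for the same change on the core of compound 1: the same change on two cores in this assay, a 1.2-fold higher number (0.08 log units; within the scatter) from compound 1 to compound 2 and a 4.6-fold lower number (0.66 log units; beyond the scatter) from compound 3 to compound 4, 5.5-fold (0.74 log units) apart, beyond the scatter of two such steps The change therefore cannot be carried from one core to the other at a fixed size. Among these compounds, this does not show why the steps differ, since the change also sits at a different place on the chain in each pair, and each core supplies only one pair, so core and place cannot be separated.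

On these data alone, it remains open whether a longer chain would keep lowering the number on either core. As far as these compounds go, how an amine or a carboxylic acid on the ester chain would read also remains open.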